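A few compounds are considered here, and "the series" means these few. Any claim that something is new, unique, unknown or untested is made for them only; others in the source may bear on it.

Compound 1 `O=c1cc(CSC(=S)N2CCCCC2)oc2cc(Cl)ccc12`: 3000 nM in a functional assay on MDA-MB-435S cells (Homo sapiens) for antiproliferative activity, read by MTT assay, with a stated time of 72 h; on this read-out lower numbers stand for stronger inhibition and higher numbers for weaker inhibition
Compound 2 `O=c1cc(CSC(=S)N2CCCC2)oc2cc(Cl)ccc12`: > 25000 nM in this assay, which is a limit of the assay rather than a number

Compound 2 therefore stands at the limit of > 25000 nM in this assay, at which 1 of the 2 values shown sits, and of the two measured compounds it is the weaker. Within the data shown here, the only measured step at the thiocarbonyl carbon is an at least 8.3-fold higher number from compound 1 to compound 2 (0.92 log units; beyond the scatter), a change that moved inhibition in the weakening direction by at least a modest amount. Compound 3 `CC(C)N(C(=S)SCc1cc(=O)c2ccc(Cl)cc2o1)C(C)C` differs from compound 2 by diisopropylamino in place of pyrrolidin-1-yl on a thiocarbonyl carbon. Among the measured compounds shown here, no measured step covers an exchange of a ring for an open-chain amine at this position, and because compound 2 sits at the limit of > 25000 nM in this assay, at which 1 of the 2 values shown sits, the size of any step from it can only be bounded from one side. Compound 3 is therefore expected to lie in the weak range, with an estimated step of an at least 1.6-fold lower number from compound 2 to compound 3 (0.22 log units; that floor lies within the scatter) in this assay, and an estimate of 15000 nM spanning 3000 nM to 60000 nM.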

Compound 3, half-maximal inhibitory concentration: > 25000 nM
Compound 3 ended at the assay's limit; the forecaster's own chance of this, stated with the estimate: 50%; at least 1.6-fold (0.22 log units) between middle value and limit.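

Compound 3 shows that the loss at the thiocarbonyl carbon is not confined to pyrrolidin-1-yl: the open-chain diisopropylamino group also fails to keep what piperidin-1-yl gives, with an at least 8.3-fold higher number from compound 1 to compound 3 (0.92 log units; beyond the scatter). In this assay compound 3 gives > 25000 nM, which is a limit of the assay and not a number. The step from compound 2 to compound 3 cannot be read, because both values are limits: the limit of > 25000 nM in this assay, at which 2 of the 3 values shown sit.

Of the three amines shown, piperidin-1-yl alone gives a value that is a number, and whether a morpholine ring, a piperazine ring or diethylamino would do the same remains open. As far as these compounds go, how compound 2 and compound 3 truly stand relative to each other also remains unknown.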